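This account rests on a few compounds, and the source may have more. Where it says the series, first, only, none or still open, it means among the compounds named here.

Working notes on the hydroxamate series. For the measured compounds named here, in an assay on Sf9 cells for inhibition of protein deacetylase HDAC6 (Homo sapiens), read by fluorescence, with a stated time of 40 min, tested at 100 nM (a higher number here means more inhibition at the concentration tested (going by the name of the read-out), a lower number less inhibition), compound 1 `Cc1cccc(-c2nc(CNc3ccc(C(=O)NO)cc3)n(-c3ccccc3)n2)c1` gives 64.1% and compound 3 `Cc1ccc(-c2nc(CNc3ccc(C(=O)NO)cc3)n(-c3ccccc3)n2)cc1` gives 62.2%; the single measured step, a number 1.9 percentage points lower from compound 1 to compound 3 (within the scatter), shows that moving the methyl between the 3-methylphenyl and 4-methylphenyl forms leaves the read-out unchanged. Compound 2 `CCc1ccc(-n2nc(-c3ccccc3)nc2CNc2ccc(C(=O)NO)cc2)cc1` gives 38.3% in this assay, the lowest of the three numbers, beyond the scatter below both compound 1 and compound 3. The step under consideration leads to compound 4 `COc1ccc(-n2nc(-c3ccccc3)nc2CNc2ccc(C(=O)NO)cc2)cc1`: methoxy in place of ethyl on an aromatic carbon. Going by the values given here, no measured pair covers this exchange; the one known step, a number 1.9 percentage points lower from compound 1 to compound 3 (within the scatter), concerns the other aryl ring of the shared core and is within the scatter, so it offers no direction for a methoxy-for-ethyl change on the aromatic carbon. With nothing in the set to pull the number either way, the expectation is no step beyond the scatter, anchored on the value of compound 2. Compound 4 is therefore estimated at 40%, with a range from 22% to 58%. The expected step is a number 1.7 percentage points higher from compound 2 to compound 4 (within the scatter), within the scatter.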

Compound 4, a percentage reported as inhibition, at one concentration (the size of the read-out at that concentration, not a potency): 63.4%
Compound 4: the middle estimate sits 23.4 percentage points below what was measured, outside the stated range (above it).
By their numbers in this assay, from the lowest: compound 2; then compounds 3, 4 and 1 (each within the scatter of the next).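

In this assay, for the compounds shown here, the single exchange of 4-ethylphenyl for 4-methoxyphenyl gives a number 25.1 percentage points higher from compound 2 to compound 4 (beyond the scatter), so this position, para to a large group, responds to a change of group in a way the earlier step did not show. That earlier step, a number 1.9 percentage points lower from compound 1 to compound 3 (within the scatter), moved a methyl on a different ring of the shared core, whereas here ethyl and methoxy have the same count of heavy atoms and the entering group brings an oxygen and a hydrogen-bond acceptor. Nothing available gives a measured reason for the step. The compounds shown leave open whether the step depends on the oxygen or on the loss of ethyl, and how an amine, a hydroxyl or ethoxy would read at this position. They also leave open whether the same exchange has a similar effect on the other aryl ring.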